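A Bromo Swap at the Toxicity Limit

The source may report more compounds than this note shows. Statements on the series, on what has been measured and on what is new or still open speak of the compounds shown alone.

Compound 1 `Brc1ccc(NCc2cn(-c3ccccc3)nc2-c2ccccc2)cc1` gives > 100000 nM
Compound 2 `FC(F)(F)c1ccc(NCc2cn(-c3ccccc3)nc2-c2ccc(Br)cc2)cc1` gives > 100000 nM

In an ADME assay on MT4 cells (Homo sapiens) for cytotoxicity, read by MTT assay, with a stated time of 96 h (on this read-out lower numbers stand for higher toxicity in this test and higher numbers for lower toxicity in this test), compound 2 has no exact number, only a limit (> 100000 nM). Compound 1 likewise has only a limit (> 100000 nM). Compound 3 `Brc1ccc(NCc2cn(-c3ccccc3)nc2-c2ccc(Br)cc2)cc1` differs from compound 2 by one swap bromo in place of trifluoromethyl on an aromatic carbon with bromo in place of trifluoromethyl on an aromatic carbon. Within the data shown here, no measured step shows what this swap does, so no change beyond the usual scatter is expected. The expected step of an at least 1.1-fold lower number from compound 2 to compound 3 (0.04 log units; that floor lies within the scatter) is therefore small. Compound 3 is estimated at 90000 nM with an expected range from 40000 nM to 100000 nM and may again give only a limit.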

Compound 3, half-maximal cytotoxic concentration: > 100000 nM
Compound 3 was reported as a limit; the forecaster's own chance of this, stated with the estimate: 65%; middle value at least 1.1-fold (0.04 log units) from the limit.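

Among these compounds, compound 1, compound 2 and compound 3 all give only a limit, so no step between them can be read: the limit of > 100000 nM in this assay, at which 3 of the 3 values shown sit. The compounds shown leave open whether their cytotoxicity differs at all.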